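Aryl exchange from compound 3 to compound 4

The compounds below may be only part of what the source reports. "The series", "measured", "known", "first", "only" and "open" are said of these compounds alone.

Values in a functional assay on THP-1 cells (Homo sapiens) for cytotoxicity, read by MTT assay, with a stated time of 24 h; on this read-out higher numbers stand for weaker inhibition and lower numbers for stronger inhibition:
- compound 1 `Cc1ccc(/C=C2\CC[C@H]3C(C)(C)CCC[C@]3(C)[C@H]2CCC(C)CC(=O)O)cc1` gives > 200000 nM as a limit of the assay
- compound 2 `CC(CC[C@H]1/C(=C/c2ccc([N+](=O)[O-])cc2)CC[C@H]2C(C)(C)CCC[C@]12C)CC(=O)O` gives 180000 nM as a number
- compound 3 `COc1ccc(/C=C2\CC[C@H]3C(C)(C)CCC[C@]3(C)[C@H]2CCC(C)CC(=O)O)cc1OC` gives 178000 nM as a number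

Among the compounds with values here, compound 3 stands within the scatter of the only other true number (a 1.0-fold lower number from compound 2 to compound 3 (0.00 log units; within the scatter)). The next change gives compound 4 `CC(CC[C@H]1/C(=C/c2ccc(Cl)cc2)CC[C@H]2C(C)(C)CCC[C@]12C)CC(=O)O` with 4-chlorophenyl in place of 3,4-dimethoxyphenyl on a double-bonded chain carbon bound to a double-bonded ring carbon. Within the data shown here, the closest precedent is the aryl exchange already cited, which stayed within the scatter. The steps starting from the limit give only floors within the scatter (an at least 1.1-fold lower number from compound 1 to compound 2 (0.04 log units; that floor lies within the scatter); an at least 1.1-fold lower number from compound 1 to compound 3 (0.05 log units; that floor lies within the scatter)). No step beyond the scatter is therefore expected in this assay (a 1.1-fold lower number from compound 3 to compound 4 (0.05 log units; within the scatter)). Compound 4 is estimated at 160000 nM (expected range 80000 nM to 200000 nM).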

Compound 4, half-maximal inhibitory concentration: > 200000 nM
Compound 4: no number, only a limit; the forecaster's own chance of this, stated with the estimate: 25%; middle value at least 1.2-fold (0.09 log units) away from the limit.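

In this assay, the first halogen on the aromatic ring gives only floors within the scatter (an at least 1.1-fold higher number from compound 3 to compound 4 (0.05 log units; that floor lies within the scatter); an at least 1.1-fold higher number from compound 2 to compound 4 (0.04 log units; that floor lies within the scatter)). The step between compound 1 and compound 4 cannot be read, since both values are limits. Exchange of 3,4-dimethoxyphenyl for 4-chlorophenyl, with its fewer heavy atoms and no hydrogen-bond acceptors, thus opens no step beyond the scatter, and the series now sits largely at the ceiling: the limit of > 200000 nM in this assay, at which 2 of the 4 values shown sit.

Open, on these data alone, is how far compound 4 lies past its limit. Also open, as far as these compounds go, is whether an amine on the aromatic ring, or an amide in place of the carboxylic acid, would give a clearly lower number in this assay.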